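This account rests on a few compounds, and the source may have more. Where it says the series, first, only, none or still open, it means among the compounds named here.

Measured so far in a functional assay on the whole organism for inhibition, with Rattus norvegicus as the target, read by paw edema, with stated times of 30 min and 2 h, at a dose of 10 mg/kg by the oral route; a lower number here means less inhibition, a higher number more inhibition at the dose given (going by the name of the read-out):

Compound 1, `O=C1N=C(C2C(=O)c3ccccc3C2=O)CC(c2ccccc2[N+](=O)[O-])N1`, gives 30%.
Compound 2, `O=C1N=C(C2C(=O)c3ccccc3C2=O)CC(c2ccc([N+](=O)[O-])cc2)N1`, gives 26%.

Both measured compounds share one core and differ only in where the nitro group sits on the phenyl ring. The step from the first to the second, a number 4 percentage points lower from compound 1 to compound 2 (within the scatter), lies within the usual scatter, so the two numbers cannot be told apart, and compound 2 stands beside compound 1 rather than apart from it.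

Compound 3, `O=C1N=C(C2C(=O)c3ccccc3C2=O)CC(c2ccc(Cl)cc2)N1`, is not yet measured. Its difference from compound 2 is chloro in place of nitro on an aromatic carbon. Among the measured compounds shown here, no measured step exchanges the nitro group for another group; the only step available moves the nitro group around the ring and stays within the scatter. For the measured compounds named here, there is thus no measured step that bears directly on this change, and nothing among the numbers points to a rise or a fall.

The expectation for compound 3 is therefore a number close to that of compound 2, with the expected step of a number 1 percentage points lower from compound 2 to compound 3 (within the scatter) lying within the scatter. Compound 3 is estimated to give 25%, with a range from 10% to 40%.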

Compound 3, a percentage reported as inhibition, in the whole organism at one dose (the size of the read-out at that dose, not a potency): 19%
Estimate against measurement, compound 3: 6 percentage points above; the range from low to high includes it.
By their numbers in this assay, from the lowest: compounds 3, 2 and 1 (each within the scatter of the next, the first and the last beyond it).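

In this assay, among the compounds shown here, replacing the nitro group with a different group for the first time gives a number 7 percentage points lower from compound 2 to compound 3 (within the scatter) in the change from 4-nitrophenyl to 4-chlorophenyl, so at this place on the ring the two groups cannot be told apart. For the compounds shown here, the comparison with the 2-nitrophenyl compound gives a number 11 percentage points lower from compound 1 to compound 3 (beyond the scatter) and is the first step here to pass beyond the ordinary spread of repeat measurements, though only modestly; since the group and its place on the ring change together, this step cannot be credited to either change alone. No measurement at hand explains either step.

A 2-chlorophenyl group would help separate the contribution of the group from that of its place on the ring, while an amine, a methoxy group or a carboxylic acid on the phenyl ring would show whether anything beyond nitro and chloro moves the reading further. Going by these compounds, each number also describes the size of the inhibition at a single oral dose, so how these compounds compare at other doses remains open.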